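Hydroxy to ((4-methylphenyl)sulfonyl)oxy on two related cores

The compounds below may be only part of what the source reports. "The series", "measured", "known", "first", "only" and "open" are said of these compounds alone.

Three compounds have been run in a functional assay on MCF7 cells (Homo sapiens) for cytotoxicity, read by MTT assay, with a stated time of 4 days; a lower number here means a stronger inhibitor, a higher number a weaker inhibitor:
- compound 1 `Cc1ccc(S(=O)(=O)Oc2ccc3c(c2C)[C@H](Cn2cc(-c4ccccn4)nn2)[C@@]24CC(=O)[C@@](C)(CC[C@@H]32)C4)cc1`; in this assay compound 1 sits at > 20000 nM, which is a limit of the assay and not a number.
- compound 2 `Cc1c(O)ccc2c1[C@H](Cn1cc(-c3ccccn3)nn1)[C@@]13CC(=O)[C@@](C)(CC[C@@H]21)C3`; in this assay compound 2 sits at > 20000 nM, again a limit.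
- compound 3 `C=C1C(=O)[C@]23C[C@@]1(O)CC[C@H]2c1ccc(O)c(C)c1[C@@H]3Cn1cc(-c2ccc(F)cc2)nn1`; in this assay compound 3 gives 1700 nM, the only number in the set.

Compound 2 and compound 1 differ in one place, ((4-methylphenyl)sulfonyl in place of hydrogen on an oxygen on an aromatic ring). The step that the two limits leave unreadable from compound 2 to compound 1 cannot be read, because both values sit at the limit of > 20000 nM in this assay, at which 2 of the 3 values shown sit. The difference between the cores of compound 2 and compound 3 is not broken down here.

Compound 4 `C=C1C(=O)[C@]23C[C@@]1(O)CC[C@H]2c1ccc(OS(=O)(=O)c2ccc(C)cc2)c(C)c1[C@@H]3Cn1cc(-c2ccc(F)cc2)nn1` is not yet measured. It differs from compound 3 by (4-methylphenyl)sulfonyl in place of hydrogen on an oxygen on an aromatic ring, the same change as that from compound 2 to compound 1, with an identical place line. Since the earlier instance of this change gives no readable size, the expectation for compound 4 rests on the value of compound 3 alone and on the chance that the new compound, like compound 1, falls to the limit. Compound 4 is expected at 5000 nM in this assay, within 1200 nM to 20000 nM. The expected step is a 2.9-fold higher number from compound 3 to compound 4 (0.47 log units; beyond the scatter), a guess weighted toward loss rather than gain.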

Compound 4, half-maximal inhibitory concentration: 330 nM
For compound 4 the middle estimate is 15-fold (1.18 log units) above the measured one; measured number below the stated range.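

In this assay, the change from hydroxy to ((4-methylphenyl)sulfonyl)oxy gives a 5.2-fold lower number from compound 3 to compound 4 (0.71 log units; beyond the scatter), so on the core of compound 3 the larger group goes with a stronger inhibitor. The same change on the other core cannot be read, because compound 2 and compound 1 both stand at a limit of the assay and not at a number: the limit of > 20000 nM in this assay, at which 2 of the 4 values shown sit. The series therefore holds a single readable instance of this change, which shows that it can lower the number on one core but does not show that the gain carries to another core, nor that it fails to, since any effect on the other core would be hidden at the limit and compound 2 and compound 3 differ in more than one place.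

From the compounds shown here alone, it remains open whether the lower number depends on the (4-methylphenyl)sulfonyl group itself or would also follow from a smaller group on the same oxygen, such as methylsulfonyl, acetyl or methyl. Going by these compounds, it is also open whether a basic amine or a carboxylic acid on that phenyl ring, in place of its methyl, would keep the gain seen with compound 4.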